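The source may hold more compounds than are shown below. What is called first, only, known or untested is meant among the compounds shown, and "the series" means these compounds.

Measured so far in a functional assay on HL-60 cells (Homo sapiens) for inhibition, read by CCK-8 assay, with a stated time of 48 h, tested at 20 uM (on this read-out lower numbers stand for less inhibition of growth and higher numbers for more inhibition of growth at the one concentration tested), are three compounds:

compound 1 `COc1ccc(S(=O)(=O)Oc2ccccc2/C=C(\C#N)C(=O)Nc2nnc(-c3cccs3)s2)cc1` gives 67%
compound 2 `N#C/C(=C\c1ccccc1OS(=O)(=O)c1ccc([N+](=O)[O-])cc1)C(=O)Nc1nnc(-c2cccs2)s1` gives 23%
compound 3 `COc1ccc(Cc2nnc(NC(=O)/C(C#N)=C/c3ccccc3OS(=O)(=O)c3ccc(C)cc3)s2)cc1` gives 25%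

Compound 2 stands level with compound 3 within the scatter and far under compound 1 (a number 44 percentage points lower from compound 1 to compound 2 (beyond the scatter)). Compound 4 `N#C/C(=C\c1ccccc1OS(=O)(=O)c1ccc([N+](=O)[O-])cc1)C(=O)Nc1nnc(Cc2cccc3ccccc23)s1` differs from compound 2 in one place ((naphthalen-1-yl)methyl in place of thiophen-2-yl on an aromatic carbon): (naphthalen-1-yl)methyl replaces thiophen-2-yl on an aromatic carbon. Among the compounds with values here, the only measured step (a number 44 percentage points lower from compound 1 to compound 2 (beyond the scatter)) was large, but it swaps methoxy for nitro at a different place, so it offers no direct guide. Within the data shown here, no measured step covers this change, so no shift beyond the scatter in this assay is expected, in either direction, though with much uncertainty. The expected change is small (a number 5 percentage points higher from compound 2 to compound 4 (within the scatter)). For compound 4 the estimate is 28% (expected range 8% to 55%).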

Compound 4, percent growth inhibition at one concentration: 18%
Compound 4: middle estimate off by 10 percentage points, on the high side; the measured number falls inside the stated range.
By their numbers in this assay, from the lowest: compounds 4, 2 and 3 (each within the scatter of the next); then compound 1.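

In this assay, the swap to (naphthalen-1-yl)methyl from thiophen-2-yl on this aromatic carbon gives a number 5 percentage points lower from compound 2 to compound 4 (within the scatter) and stays within the scatter. With nitro present, this position therefore accepts a group of 11 heavy atoms in place of one of 5 with no readable change in growth inhibition. No available evidence explains this result.

Still open, from the compounds shown here alone, is how an amine or a carboxylic acid would behave on this carbon, and whether the same swap would also leave the number unchanged with methoxy in place of nitro.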